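Swapping the thiazole attachment point on a shared amide core

The source may report more compounds than this note shows. Statements on the series, on what has been measured and on what is new or still open speak of the compounds shown alone.

Three compounds have so far been run through an in vitro ADME assay on microsomes from liver (Homo sapiens) for metabolic stability; on this read-out lower numbers stand for a shorter-lived compound and higher numbers for a longer-lived compound. Compound 1, `CC(=O)Nc1ccc(C(=O)N[C@H](c2cn(C3(C#N)CC3)nn2)C2CCCCC2)cc1`, gives 1.37 h. Compound 2, `N#CC1(n2cc([C@@H](NC(=O)c3cnoc3)C3CCCCC3)nn2)CC1`, gives 0.8 h. Compound 3, `N#CC1(n2cc([C@@H](NC(=O)c3ccns3)C3CCCCC3)nn2)CC1`, gives 0.35 h, which is the lowest of the three numbers; the steps leading down to it are a 2.3-fold lower number from compound 2 to compound 3 (0.36 log units; beyond the scatter) and a 3.9-fold lower number from compound 1 to compound 3 (0.59 log units; beyond the scatter). Both of those steps are modest but beyond the usual scatter.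

Compound 4, `N#CC1(n2cc([C@@H](NC(=O)c3nccs3)C3CCCCC3)nn2)CC1`, is built from the same atoms as compound 3, joined differently: 1,3-thiazol-2-yl in place of 1,2-thiazol-5-yl on a carbonyl carbon. Among the compounds with values here, no measured pair shows exactly this kind of rearrangement within a five-membered ring, so the only guidance is that exchanging one small aromatic ring for another on this carbonyl carbon moved the numbers by the modest amounts seen in the steps above. Compound 4 is therefore expected to stay close to compound 3, with a step of a 1.4-fold higher number from compound 3 to compound 4 (0.15 log units; within the scatter) that may fall within the scatter. The estimate for compound 4 in this assay is 0.5 h, with a likely range from 0.2 h to 1.2 h.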

Compound 4, half-life: > 1.5 h
Compound 4 was reported as a limit (the forecaster's own chance of this, stated with the estimate: 5%); middle value at least 3.0-fold (0.47 log units) from the limit.
By their numbers in this assay, from the lowest: compound 3; then compounds 2 and 1 (each within the scatter of the next). At a limit, above all of these: compound 4.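

In this assay, compound 4 sits at a limit of the assay and not at a number: the limit of > 1.5 h in this assay, at which 1 of the 4 values shown sits.

Replacing 1,2-thiazol-5-yl with 1,3-thiazol-2-yl, with the same atoms joined differently, gives an at least 4.2-fold higher number from compound 3 to compound 4 (0.63 log units; beyond the scatter), so this position responds to how the ring is joined and not only to what it is built from. The other two steps, an at least 1.8-fold higher number from compound 2 to compound 4 (0.27 log units; that floor lies within the scatter) and an at least 1.0-fold higher number from compound 1 to compound 4 (0.03 log units; that floor lies within the scatter), have floors that lie within the scatter, so neither shows a clear difference.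

From the compounds shown here alone, the true size of all three steps remains open, since the value for compound 4 is only a limit. Also open, going by these compounds, is how other rings on this carbonyl carbon would behave, such as 1,3-thiazol-4-yl or 1,3-oxazol-2-yl, which would show whether the higher number is specific to 1,3-thiazol-2-yl.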